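The source may hold more compounds than are shown below. What is called first, only, known or untested is meant among the compounds shown, and "the series" means these compounds.

Compound 1 `O=C(COc1cccc2ccccc12)N/N=C/c1ccc(Cl)cc1` gives 4.54 in a physicochemical assay for lipophilicity, measured as octanol-water partition; a higher number here means a more lipophilic compound, a lower number a more polar compound.
Compound 2 `O=C(COc1cccc2ccccc12)N/N=C/c1ccccc1O` gives 3.73.
Compound 3 `O=C(COc1cccc2ccccc12)N/N=C/c1ccccc1` gives 4.02.

Among these three numbers compound 3 stands second highest: compound 2 is its nearest neighbour, separated by a gap within the scatter (a number 0.29 log units higher from compound 2 to compound 3 (within the scatter)), while compound 1 lies furthest away, above it and beyond the scatter. Compound 4 `O=C(COc1cccc2ccccc12)N/N=C/c1ccc(Br)cc1` is the next compound, differing from compound 3 by bromo in place of hydrogen on an aromatic carbon. The measured step that bears on this change is a number 0.52 log units lower from compound 1 to compound 3 (beyond the scatter), which removed a halogen from the same aromatic carbon and lowered the number. Adding bromo is expected to reverse that and to lift the number beyond the scatter, an expected step of a number 0.63 log units higher from compound 3 to compound 4 (beyond the scatter). For compound 4 the estimated value in this assay is 4.65, with a range from 4.35 to 4.95.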

Compound 4, partition coefficient: 4.81
Compound 4: middle estimate off by 0.16 log units, on the low side; the range from low to high includes it.
By their numbers in this assay, from the lowest: compounds 2 and 3 (each within the scatter of the next); then compounds 1 and 4 (each within the scatter of the next).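

In this assay bromo in place of hydrogen gives a number 0.79 log units higher from compound 3 to compound 4 (beyond the scatter) on the same aromatic carbon where chloro also goes with a higher number, so both halogens tried here point the same way. Bromo in place of chloro gives a number 0.27 log units higher from compound 1 to compound 4 (within the scatter) and so leaves the two halogens apart by no more than the usual noise. Against the 2-hydroxyphenyl group, 4-bromophenyl gives a number 1.08 log units higher from compound 2 to compound 4 (beyond the scatter) and this is the widest step among these compounds.

Where an amine or a carboxylic acid at this position would fall remains open. No measurement here accounts for these steps.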